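Chain-end methoxy on the shared core

A few compounds are considered here, and "the series" means these few. Any claim that something is new, unique, unknown or untested is made for them only; others in the source may bear on it.

Among the compounds with values here, compound 2 `CCCNc1nc(N)nc2ccccc12` gives 0.93 uM in an ADME assay on HEK293 cells for agonist activity at Toll-like receptor 8 (Homo sapiens), read by a luciferase reporter, with a stated time of 6 h; a higher number here means that more compound is needed for the effect, a lower number that less compound is needed; this is the larger of the two numbers so far, but the gap to compound 1 `CCNc1nc(N)nc2ccccc12`, which gives 0.77 uM, lies within the scatter, so no order between them is claimed. Within the data shown here, compound 3 `COCCCNc1nc(N)nc2ccccc12` is the next member. methoxy in place of hydrogen on a saturated chain carbon, three bonds along the chain from a nitrogen on an aromatic ring The only measured step that bears on it is the chain extension a 1.2-fold higher number from compound 1 to compound 2 (0.08 log units; within the scatter), which left the number essentially where it was. Among the measured compounds shown here, no measured pair shows a methoxy entering anywhere, so that part of the change has no precedent here. Taking the methoxy as a further extension of the same chain, the step is expected to be small, a 1.3-fold higher number from compound 2 to compound 3 (0.11 log units; within the scatter). Compound 3 is therefore estimated at 1.2 uM, with a range of 0.4 uM to 4 uM reflecting the lack of direct precedent.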

Compound 3, minimum effective concentration: 0.01 uM
Beside the measured number, compound 3's estimate is 120-fold (2.08 log units) above it, and the stated range ends above it.
By their numbers in this assay, from the lowest: compound 3; then compounds 1 and 2 (each within the scatter of the next).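

In this assay this chain position is far from flat, although the earlier pair gave only a 1.2-fold higher number from compound 1 to compound 2 (0.08 log units; within the scatter): going from propyl to 3-methoxypropyl brings a 93-fold lower number from compound 2 to compound 3 (1.97 log units; beyond the scatter). Methoxymethyl in place of hydrogen on the ethyl chain brings a step of the same order, a 77-fold lower number from compound 1 to compound 3 (1.89 log units; beyond the scatter), so the large drop in the number holds against either shorter chain. No measurement on hand accounts for the size of these steps.

The compounds shown leave open whether the oxygen or the added chain length carries the step, which a plain butyl or pentyl chain would separate. Also open, on these data alone, is how far the result depends on the group at the chain end and its place, as with a hydroxyl, an amine or a 2-methoxyethyl chain.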